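From furan-2-yl to ethyl: a step past the limits

This account rests on a few compounds, and the source may have more. Where it says the series, first, only, none or still open, it means among the compounds named here.

Of the compounds shown here, three have been tested so far in an ADME assay on MDCK cells (Canis lupus familiaris) for cytotoxicity, read by MTT assay, with a stated time of 24 h; on this read-out lower numbers stand for higher toxicity in this test and higher numbers for lower toxicity in this test. Compound 1 (`N#CCCN(Cc1cccs1)S(=O)(=O)c1ccc(Br)cc1`) gives > 173000 nM, which is a limit and not a number. Compound 2 (`CCCN(Cc1cccs1)S(=O)(=O)c1ccc(Br)cc1`) gives > 178000 nM, which is also a limit. Compound 3 (`N#CCCN(Cc1ccco1)S(=O)(=O)c1ccc(Br)cc1`) gives > 180000 nM, again a limit. Compound 3 therefore has no exact place on the scale, and the other two values shown are limits as well.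

Compound 4 (`CCCN(CCC#N)S(=O)(=O)c1ccc(Br)cc1`) differs from compound 3 in one place, with ethyl in place of furan-2-yl on a saturated chain carbon bound to a sulfonamide nitrogen.

Within the data shown here, two measured steps bear on this change. Furan-2-yl in place of thiophen-2-yl, at that same place, is a step that the two limits leave unreadable from compound 1 to compound 3. Methyl in place of cyano, on a saturated chain carbon two bonds along the chain from a sulfonamide nitrogen, is a step that the two limits leave unreadable from compound 1 to compound 2. Among the measured compounds shown here, neither step gives a size to build on, so the only guide is where these compounds stand.

The expected change is a step that the limit leaves unreadable from compound 3 to compound 4, which is estimated to lie within the usual scatter of this assay, in neither direction. For compound 4 the estimated value is 200000 nM, with an expected range from 100000 nM to 300000 nM, and it may well be reported as a limit too.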

Compound 4, half-maximal cytotoxic concentration: 116000 nM
The estimate for compound 4 lay 1.7-fold (0.24 log units) above the measured number; the measured number falls inside the stated range.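

In this assay only compound 4 gives an exact number rather than a limit, so this place, the saturated chain carbon bound to a sulfonamide nitrogen, now has a first readable direction: ethyl in place of furan-2-yl gives an at least 1.5-fold lower number from compound 3 to compound 4 (0.19 log units; that floor lies within the scatter). The thiophen-2-yl compounds point the same way, with ethyl in its place giving an at least 1.4-fold lower number from compound 1 to compound 4 (0.17 log units; that floor lies within the scatter) and cyanomethyl in its place giving an at least 1.5-fold lower number from compound 2 to compound 4 (0.18 log units; that floor lies within the scatter). Each of these steps is only a floor because its starting compound carries a limit, as compound 3 does: the limit of > 180000 nM in this assay, at which 1 of the 4 values shown sits.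

Going by these compounds, with floors alone, it stays open whether compound 4 truly differs from the ring-bearing compounds by more than the usual scatter, and the true gap could be small or much larger. On these data alone, it is also open whether the ring or the chain is what matters at this place, which a phenyl ring, a longer chain such as butyl, or an amine on the same carbon could help to separate.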